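A few compounds are considered here, and "the series" means these few. Any claim that something is new, unique, unknown or untested is made for them only; others in the source may bear on it.

Compound 1 `ClCc1ccc(Cn2cnc3c(Cl)ncnc32)cc1` is the reference point of this small set. In a functional assay on MCF7 cells (Homo sapiens) for cytotoxicity, read by sulforhodamine B assay, with a stated time of 48 h (a higher number here means a weaker inhibitor of growth, a lower number a stronger inhibitor of growth), compound 1 gives 410 nM. Compound 2 `Nc1nc(Cl)c2ncn(Cc3ccc(CCl)cc3)c2n1` carries one added group; the change is amino in place of hydrogen on an aromatic carbon, and its effect is a 6.9-fold higher number from compound 1 to compound 2 (0.84 log units; beyond the scatter), so that in this assay compound 2 gives 2820 nM. Compound 3 `ClCc1ccccc1Cn1cnc2c(Cl)ncnc21` has the same atoms as compound 1 joined differently; the difference between the two cores is not broken down here. In this assay compound 3 gives 11000 nM, the highest number of the three, beyond the scatter from both of the others.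

Compound 4 `Nc1nc(Cl)c2ncn(Cc3ccccc3CCl)c2n1` is not yet measured. For the measured compounds named here, it differs from compound 3 by amino in place of hydrogen on an aromatic carbon, the same change, at a place described in the same words, as the one from compound 1 to compound 2. Going by the values given here, the account expects the step from compound 3 to compound 4 to be about a 5.5-fold higher number from compound 3 to compound 4 (0.74 log units; beyond the scatter), resting on the single earlier instance, a 6.9-fold higher number from compound 1 to compound 2 (0.84 log units; beyond the scatter). On that basis compound 4 is estimated at 60000 nM in this assay, within a range from 15000 nM to 200000 nM, with some chance that only a limit is reported.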

Compound 4, concentration for 50% growth inhibition: 6030 nM
For compound 4 the middle estimate is 10-fold (1.00 log units) above the measured one; the measured number lies below the stated range.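

In this assay, amino in place of hydrogen on an aromatic carbon does not carry over from one core to the other as a fixed step: the same change on two cores in this assay, a 6.9-fold higher number (0.84 log units; beyond the scatter) from compound 1 to compound 2 and a 1.8-fold lower number (0.26 log units; within the scatter) from compound 3 to compound 4, 13-fold (1.10 log units) apart, beyond the scatter of two such steps

On the core of compound 3, the change gives a 1.8-fold lower number from compound 3 to compound 4 (0.26 log units; within the scatter), so a clear shift appears only on the core of compound 1. These two pairs show that a step read on one core of this series cannot simply be transferred to the other, but they do not show what sets the cores apart, and they give no rule for any further core.

The compounds shown leave open how a hydroxyl or a methylamino group would behave in the place of the amino group on either core, and whether a bromomethyl group in place of chloromethyl would alter the gap between the two steps. They also leave open whether that gap would persist in any other cell line.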